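This account rests on a few compounds, and the source may have more. Where it says the series, first, only, none or still open, it means among the compounds named here.

Compound 2 `CCCCCCCCc1ccc(OCC(=O)Cn2nnc(C)n2)cc1` gives < 5% in an ADME assay on S9 fraction from liver (Rattus norvegicus) for metabolic stability, read by LC-MS, using NADPH, with a stated time of 30 min (a lower number here means that less of the compound is left, a higher number that more of the compound is left), and this is a limit of the assay, not a number. Compound 1 `CCCCCCCCc1ccc(OCC(=O)Cn2ncnn2)cc1` gives < 5% in this assay and this too is a limit. Between these two stands a step that the two limits leave unreadable from compound 1 to compound 2 and it gives no usable size for the methyl group. Compound 3 `CCCCCCCCc1ccc(OCC(=O)Cn2nnc(-c3cccc(Cl)c3)n2)cc1` gives a real number, with 69% left in this assay after the incubation. Its 3-chlorophenyl group brings a number at least 64 percentage points higher from compound 1 to compound 3 (beyond the scatter) and also a number at least 64 percentage points higher from compound 2 to compound 3 (beyond the scatter) in the same assay.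

The step now followed leads to compound 4 `CCCCCCCCc1ccc(OCC(=O)Cn2nnc(-c3ccc(C(=O)OC)cc3)n2)cc1`, which differs from compound 2 as follows: 4-(methoxycarbonyl)phenyl in place of methyl on an aromatic carbon in the same place where compound 3 carries its 3-chlorophenyl group. The nearest guide is therefore compound 3, with its a number at least 64 percentage points higher from compound 2 to compound 3 (beyond the scatter) as the closest measured precedent. Within the data shown here, no measured compound carries the methoxycarbonyl group, so that precedent transfers only in part, and the expected range stays wide. A large upward step is therefore expected, estimated as a number at least 40 percentage points higher from compound 2 to compound 4 (beyond the scatter) in this assay for this change. Compound 4 is expected to give about 45% with an estimated range from 12% to 78% in this measurement.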

Compound 4, percent of the compound remaining: 64%
The estimate for compound 4 lay 19 percentage points below the measured number; the measured number falls inside the stated range.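

Compound 4 shows that the large upward step at this place, an aromatic carbon of the five-membered aromatic ring with 4 nitrogen, does not belong to the 3-chlorophenyl group alone, since a phenyl ring bearing a quite different substituent also gives a number at least 59 percentage points higher from compound 2 to compound 4 (beyond the scatter) and a number at least 59 percentage points higher from compound 1 to compound 4 (beyond the scatter) in this assay. The two aryl groups are not told apart by this read-out, with a number 5 percentage points lower from compound 3 to compound 4 (within the scatter), so among the four compounds both that carry a six-membered aromatic ring here stand clear of the two that carry hydrogen or methyl, and none of the four goes against this. Compound 2 gives < 5%, which is a limit and not a number, so the upward steps that start from it give only a minimum size: the limit of < 5% in this assay, at which 2 of the 4 values shown sit.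

On these data alone, it stays open whether a plain phenyl group with no substituent would be enough, or whether a carboxylic acid or an amine on that phenyl ring would keep the compound at a similar level in this assay. The compounds shown also leave open how far this holds with a shorter chain on the shared core, since all four carry the same chain.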